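Adding a methyl to the sulfur chain of compound 2

A few compounds are considered here, and "the series" means these few. Any claim that something is new, unique, unknown or untested is made for them only; others in the source may bear on it.

Working notes on the series, read in an ADME assay on MT4 cells (Homo sapiens) for activation, read by MTT assay; a higher number here means that more compound is tolerated, a lower number that less compound is tolerated. Compound 2 (`CCCSc1nc(Cc2c(F)cccc2Cl)c(C)c(=O)[nH]1`) gives > 76000 nM, which is a limit of the assay and not a number. Compound 1 (`CCC(C)Sc1nc(Cc2c(F)cccc2Cl)cc(=O)[nH]1`) gives > 76000 nM, which is also a limit. Among the compounds with values here, the series therefore holds no exact value so far, and the position of compound 2 is the limit of > 76000 nM in this assay, at which 2 of the 2 values shown sit.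

Compound 3 (`CCC(C)Sc1nc(Cc2c(F)cccc2Cl)c(C)c(=O)[nH]1`) follows from compound 2 through one change: methyl in place of hydrogen on a saturated chain carbon bound to a saturated chain carbon and a sulfur. In other words, methyl replaces hydrogen on a saturated chain carbon bound to a saturated chain carbon and a sulfur, turning propylsulfanyl into (sec-butyl)sulfanyl.

Within the data shown here, no measured step between compounds is available to size this change. No step beyond the usual scatter is expected in this assay, and neither direction is favoured. This expectation rests on compound 2, whose > 76000 nM is a limit. The estimated step that the limit leaves unreadable from compound 2 to compound 3 stays within the scatter. For compound 3 the expected value is 80000 nM, with an estimated range of 35000 nM to 160000 nM, and a report as a limit is the likeliest outcome.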

Compound 3, half-maximal cytotoxic concentration: > 73000 nM
Compound 3: no number, only a limit (the forecaster's own chance of this, stated with the estimate: 75%); the middle value is on the limit's open side.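

In this assay, within the data shown here, compound 1, compound 2 and compound 3 are all reported only as limits, so neither the step to compound 3 from compound 2 nor the one from compound 1 can be read. The compounds shown leave open whether either methyl shifts the half-maximal cytotoxic concentration at all, and in which direction.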